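A Benzylsulfanyl Swap at the Limit of the Assay

The source may hold more compounds than are shown below. What is called first, only, known or untested is meant among the compounds shown, and "the series" means these compounds.

Compound 1 `COc1ccc([C@@H]2c3c(OC)cc(OC)cc3C(=O)[C@H]2c2cc(OC)cc(OC)c2)cc1` was tested in a functional assay on RAW264.7 cells (Mus musculus) for inhibition, with stated times of 2 h and 24 h (on this read-out lower numbers stand for stronger inhibition and higher numbers for weaker inhibition), and gives > 200000 nM, which is a limit and not a number. Compound 2 `COc1cc(OC)cc([C@@H]2C(SCc3ccccc3)c3cc(OC)cc(OC)c3[C@H]2c2ccccc2)c1` gives > 200000 nM, also a limit. Compound 3 `COc1ccc([C@@H]2c3c(OC)cc(OC)cc3C(SCc3ccccc3)[C@H]2c2cc(OC)cc(OC)c2)cc1` gives > 200000 nM, again a limit. The three therefore share one position: the limit of > 200000 nM in this assay, at which 3 of the 3 values shown sit. Compound 3 thus has no exact value from which to count.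

Compound 4 `COc1ccc([C@@H]2c3c(OC)cc(OC)cc3C(C(O)c3ccc(Cl)cc3)[C@H]2c2cc(OC)cc(OC)c2)cc1` carries (4-chlorophenyl)(hydroxy)methyl in place of benzylsulfanyl on a saturated ring carbon.

For the measured compounds named here, the only measured step is a step that the two limits leave unreadable from compound 2 to compound 3, with methoxy in place of hydrogen on an aromatic carbon. That step is a different change and has no readable size, so the measurements set no size for the new one. At most a modest move towards stronger inhibition in this assay is expected, and a result at the same limit remains the likeliest outcome. The expected step is an at least 1.3-fold lower number from compound 3 to compound 4 (0.12 log units; that floor lies within the scatter). For compound 4 the estimated value is 150000 nM, with an expected range from 40000 nM to 300000 nM.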

Compound 4, half-maximal inhibitory concentration: > 200000 nM
Compound 4 was reported as a limit; the forecaster's own chance of this, stated with the estimate: 60%; middle value at least 1.3-fold (0.12 log units) from the limit.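

Compound 4 sits at a limit, as compound 3 does, so the step between them cannot be read in this assay. With every value shown at one limit, the compounds leave open which change to the shared core, if any, would give an exact value in this assay.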